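An amide step from compound 1 to compound 4

A few compounds are considered here, and "the series" means these few. Any claim that something is new, unique, unknown or untested is made for them only; others in the source may bear on it.

Of the compounds shown here, three have so far been measured in a functional assay on Bel-7402 cells (Homo sapiens) for inhibition, read by MTT assay, with a stated time of 24 h, tested at 100 ug/mL; on this read-out lower numbers stand for less inhibition of growth and higher numbers for more inhibition of growth at the one concentration tested. Compound 1 (`CC(=O)SCCC(CCCCC(=O)O)SC(C)=O`) gives 8.35%. Compound 2 (`O=C(CCCCC1CCSS1)Nc1ccccc1Cl`) gives 4.74%, which lies within the scatter of the value for compound 1. Compound 3 (`O=C(CCCCC(S)CCS)Nc1ccc(Cl)cc1`) gives 25.5%, and that value lies beyond the scatter from compound 1, which therefore stands level with compound 2 and clearly under compound 3.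

Compound 4 (`CC(=O)SCCC(CCCCC(=O)Nc1ccccc1Cl)SC(C)=O`) has not yet been measured. It differs from compound 1 by (2-chlorophenyl)amino in place of hydroxy on a carbonyl carbon, with (2-chlorophenyl)amino in place of hydroxy on a carbonyl carbon. For the measured compounds named here, no measured pair isolates this change, so the evidence is indirect. Compound 2 carries the same (2-chlorophenyl)amino group and stays at 4.74%, while compound 3, also an amide, reaches 25.5%. A small rise in this assay is therefore expected, though not one beyond the scatter. The expected change is a number 5.7 percentage points higher from compound 1 to compound 4 (within the scatter). The estimate for compound 4 is 14%, with an expected range of 3% to 32%.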

Compound 4, percent growth inhibition at one concentration: "not active" (no number reported)
Nothing numeric was reported for compound 4; no gap can be computed for the estimate.
By their numbers in this assay, from the lowest: compounds 2 and 1 (each within the scatter of the next); then compound 3.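

For the compounds shown here, compound 4 is reported in this assay only as "not active", without a number, so no step from compound 1 to compound 4 can be read. The compounds shown leave open how far (2-chlorophenyl)amino in place of hydroxy changes growth inhibition. Nothing shown bears on the reason for this result.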